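The compounds below may be only part of what the source reports. "The series", "measured", "known", "first", "only" and "open" are said of these compounds alone.

In a functional assay on HL-60 cells (Homo sapiens) for antiproliferative activity, read by MTT assay, with a stated time of 72 h (on this read-out higher numbers stand for weaker inhibition and lower numbers for stronger inhibition), compound 1 `NC1=NC2(CCSCC2)N(OCCCOc2ccc(Br)cc2)C(N)=N1` gives 350 nM and stands with its two measured relatives, with no separation from either. Compound 2 `NC1=NC2(CCOCC2)N(OCCCOc2ccc(Cl)cc2Cl)C(N)=N1` gives 330 nM and compound 3 `NC1=NC2(CCOCC2)N(OCCCOc2ccccc2Br)C(N)=N1` gives 610 nM in the same read-out, and all three values lie within the scatter of one another. The step followed here leads to compound 4 `COc1ccc(OCCCON2C(N)=NC(N)=NC23CCSCC3)cc1`, which keeps the core of compound 1 and differs in one place: methoxy in place of bromo on an aromatic carbon describes methoxy in place of bromo on an aromatic carbon, para to a large group. No measured step exchanges bromo for methoxy, so nothing shown tests this change directly. Within the data shown here, the only single-place step available is a 1.8-fold higher number from compound 2 to compound 3 (0.27 log units; within the scatter) and it involves other substituents on the phenyl ring, so it bears on this change only loosely. That step stays within the scatter, and no measured gap in this small set goes beyond it, so no step beyond the scatter is expected in this assay for compound 4. The estimated change is a 1.3-fold higher number from compound 1 to compound 4 (0.11 log units; within the scatter) and its direction is not secured by the data. For compound 4 the expected value is 450 nM with an estimated range from 150 nM to 1300 nM for repeated measurements.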

Compound 4, half-maximal inhibitory concentration: 500 nM
Beside the measured number, compound 4's estimate is 1.1-fold (0.05 log units) below it; the range from low to high includes it.
By their numbers in this assay, from the lowest: compounds 2, 1, 4 and 3 (each within the scatter of the next).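

In this assay the exchange of 4-bromophenyl for 4-methoxyphenyl gives a 1.4-fold higher number from compound 1 to compound 4 (0.15 log units; within the scatter) and so provides the first direct test of this position, which the earlier step could address only loosely through other substituents on the phenyl ring. The position accepts methoxy, with two heavy atoms and one hydrogen-bond acceptor, in place of bromo, with one heavy atom and no hydrogen-bond acceptor, and the two compounds cannot be told apart in this read-out. No measurement of any property of these compounds bears on this result, so the data offer no explanation for it.

The compounds shown leave open whether this position would also tolerate a different kind of group, such as an amine, a carboxylic acid or a nitrile, para to a large group on the same ring. Among these compounds, they also leave open whether the exchange of bromo for methoxy reads the same on the core of compound 2, and whether a longer chain in place of the one these compounds share would keep the values within the scatter of one another.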